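The source may report more compounds than this note shows. Statements on the series, on what has been measured and on what is new or still open speak of the compounds shown alone.

Measured so far in a functional assay on MV4-11 cells (Homo sapiens) for inhibition, read by resazurin assay, with a stated time of 72 h; on this read-out higher numbers stand for weaker inhibition of growth and lower numbers for stronger inhibition of growth:
- compound 1 `Cc1ccc(-c2cncc(Cl)c2N2CCC3(CCNC3=O)CC2)s1`: 650 nM
- compound 2 `O=C1NCCC12CCN(c1c(Cl)cncc1-c1ccc(-c3ccccc3)s1)CC2`: 960 nM

Only these two compounds have numbers, and compound 2 lies within the scatter of compound 1, so no order can be read between them.

Next comes compound 3 `O=C1NCCC12CCN(c1c(Cl)cncc1-c1ccc(CN3CCCC3)s1)CC2`, which keeps the core of compound 2. The change is (pyrrolidin-1-yl)methyl in place of phenyl on an aromatic carbon.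

Within the data shown here, one measured step bears on this: a 1.5-fold higher number from compound 1 to compound 2 (0.17 log units; within the scatter). It involves the same aromatic carbon and stays within the scatter, so methyl and phenyl cannot be told apart there. Among the measured compounds shown here, neither group contains a nitrogen, and no measured compound has a (pyrrolidin-1-yl)methyl group, so the data give no direct guide to this replacement.

With compound 2 at 960 nM as the starting point, no shift beyond the scatter is expected, although the uncertainty is wide. The expected change is a 1.2-fold lower number from compound 2 to compound 3 (0.08 log units; within the scatter). In this assay the estimate for compound 3 is 800 nM, with an expected range of 250 nM to 2500 nM.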

Compound 3, concentration for 50% growth inhibition: 3370 nM
Estimate against measurement, compound 3: 4.2-fold (0.62 log units) below, and the stated range ends below it.
By their numbers in this assay, from the lowest: compounds 1 and 2 (each within the scatter of the next); then compound 3.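

In this assay, the aromatic carbon next to the ring sulfur does respond to what it carries: methyl and phenyl could not be told apart there, but (pyrrolidin-1-yl)methyl in place of phenyl gives a 3.5-fold higher number from compound 2 to compound 3 (0.55 log units; beyond the scatter), a modest loss of growth inhibition. Read from the methyl group instead, with pyrrolidin-1-yl on the saturated chain carbon bound to the aromatic carbon, the step is a 5.2-fold higher number from compound 1 to compound 3 (0.71 log units; beyond the scatter), so the loss appears from both measured starting points. Phenyl and (pyrrolidin-1-yl)methyl have the same heavy-atom count and differ in the entering nitrogen and the non-aromatic ring, but no measurement on hand explains the loss.

As far as these compounds go, whether the loss follows the nitrogen or the non-aromatic ring remains open, and a cyclopentylmethyl group, with carbon in place of that nitrogen, would separate the two. Also open, from the compounds shown here alone, is whether any nitrogen-bearing group at this carbon behaves the same way, as a morpholin-4-ylmethyl group, a primary aminomethyl group or a longer chain ending in pyrrolidine would show.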